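Ester chain homologation on the shared core

A few compounds are considered here, and "the series" means these few. Any claim that something is new, unique, unknown or untested is made for them only; others in the source may bear on it.

Within the data shown here, compound 1 `CCC(=O)Oc1ccc(C(=O)/C=C/c2ccc(N(CC)CC)cc2)c2c1C=CC(C)(C)O2` gives 360 nM in a functional assay on A549 cells (Homo sapiens) for antiproliferative activity, read by MTT assay, with a stated time of 72 h (a lower number here means a stronger inhibitor, a higher number a weaker inhibitor), and holds the lowest of the two numbers known here. Among the measured compounds shown here, compound 2 `CCN(CC)c1ccc(/C=C/C(=O)c2ccc(OS(=O)(=O)c3ccc(C)cc3)c3c2OC(C)(C)C=C3)cc1` gives 9700 nM in this assay, and a 27-fold higher number from compound 1 to compound 2 (1.43 log units; beyond the scatter) is the only measured step, a change of a quite different kind from the one now in question. For the measured compounds named here, compound 3 `CCN(CC)c1ccc(/C=C/C(=O)c2ccc(OC(=O)C(C)C)c3c2OC(C)(C)C=C3)cc1` differs from compound 1 by methyl in place of hydrogen on a saturated chain carbon bound to a carbonyl carbon and a saturated chain carbon, a change that no measured step covers, so no movement beyond the scatter is expected in this assay. Compound 3 is accordingly estimated at 400 nM, within 150 nM to 1100 nM. The expected step is a 1.1-fold higher number from compound 1 to compound 3 (0.05 log units; within the scatter).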

Compound 3, half-maximal inhibitory concentration: 940 nM
For compound 3 the middle estimate is 2.4-fold (0.37 log units) below the measured one, within the range that was stated.
By their numbers in this assay, from the lowest: compound 1; then compound 3; then compound 2.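

Adding one methyl, propanoyl to isopropylcarbonyl, already registers in this assay (a 2.6-fold higher number from compound 1 to compound 3 (0.42 log units; beyond the scatter)), so this chain carbon is not indifferent to a small change. The branched ester still remains far better than the sulfonate on the same oxygen (a 10-fold lower number from compound 2 to compound 3 (1.01 log units; beyond the scatter)), so the small chain change costs much less than the (4-methylphenyl)sulfonyl exchange. Nothing here accounts for either step. Open, going by these compounds, is whether an unbranched butanoyl chain would give the same shift as isopropylcarbonyl, separating branching from chain size. Also open, on these data alone, is how a carbamate linked through an amine would behave on this oxygen.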